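Swapping a para methoxy for chloro on the pendant phenyl

A few compounds are considered here, and "the series" means these few. Any claim that something is new, unique, unknown or untested is made for them only; others in the source may bear on it.

Of the compounds shown here, three that share one core have been measured in a functional assay on HT-29 cells (Homo sapiens) for inhibition, read by MTT assay, with a stated time of 72 h; on this read-out higher numbers stand for weaker inhibition and lower numbers for stronger inhibition. Compound 1 `COc1cc2c(Oc3ccc(NC(=O)c4nn(-c5ccccc5)c(=O)cc4C)cc3F)ccnc2cc1OCCCN1CCCC1` gives 220 nM. Compound 2 `COc1cc2c(Oc3ccc(NC(=O)c4nn(-c5ccccc5C)c(=O)cc4C)cc3F)ccnc2cc1OCCCN1CCCC1` gives 1400 nM, and compound 3 `COc1ccc(-n2nc(C(=O)Nc3ccc(Oc4ccnc5cc(OCCCN6CCCC6)c(OC)cc45)c(F)c3)c(C)cc2=O)cc1` gives 3300 nM. Compound 3 therefore stands highest of the three, which on this read-out means the weakest inhibition; the step of a 15-fold higher number from compound 1 to compound 3 (1.18 log units; beyond the scatter) is the largest shift seen, and the step of a 2.4-fold higher number from compound 2 to compound 3 (0.37 log units; beyond the scatter) is smaller but still beyond the scatter.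

Compound 4 `COc1cc2c(Oc3ccc(NC(=O)c4nn(-c5ccc(Cl)cc5)c(=O)cc4C)cc3F)ccnc2cc1OCCCN1CCCC1` differs from compound 3 by chloro in place of methoxy on an aromatic carbon. Among the compounds with values here, no measured pair shows chloro replacing methoxy, so the closest guide is what the para methoxy itself did: compound 1 carries a plain phenyl and sits lowest, while adding the methoxy cost a 15-fold higher number from compound 1 to compound 3 (1.18 log units; beyond the scatter). A chloro at the same place is a different substituent, and the most reasonable expectation is a number somewhere between compound 1 and compound 3 rather than beyond either, with wide uncertainty. In this assay, compound 4 is therefore expected to give about 1200 nM, within 350 nM to 5000 nM. That estimate corresponds to an expected step of a 2.8-fold lower number from compound 3 to compound 4 (0.44 log units; beyond the scatter), a modest improvement, because the methoxy that brought a 15-fold higher number from compound 1 to compound 3 (1.18 log units; beyond the scatter) is removed while a new para substituent remains.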

Compound 4, half-maximal inhibitory concentration: 260 nM
Compound 4: middle estimate off by 4.6-fold (0.66 log units), on the high side, and the stated range ends above it.
By their numbers in this assay, from the lowest: compounds 1 and 4 (each within the scatter of the next); then compound 2; then compound 3.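

With chloro in place of methoxy on this aromatic carbon, para to a large group, this assay shows a 13-fold lower number from compound 3 to compound 4 (1.10 log units; beyond the scatter), so a group at this place does not by itself bring a large rise in the number. Chloro in place of hydrogen gives a 1.2-fold higher number from compound 1 to compound 4 (0.07 log units; within the scatter), a difference within the scatter, which means that compound 1 and compound 4 cannot be told apart here and that the rise seen with methoxy does not extend to every group at this carbon. The chlorine-bearing ring also compares well with the ring of compound 2, as 4-chlorophenyl in place of 2-methylphenyl gives a 5.4-fold lower number from compound 2 to compound 4 (0.73 log units; beyond the scatter), so the choice of substituted phenyl on the aromatic nitrogen matters a great deal in this series.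

No measurement at hand explains why methoxy and chloro part so sharply at this carbon. Going by these compounds, it also remains open whether a fluoro, an amine, a carboxylic acid or a longer chain such as ethoxy at the same place would behave like chloro or like methoxy.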